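The source may report more compounds than this note shows. Statements on the series, on what has been measured and on what is new or still open speak of the compounds shown alone.

Measured in an ADME assay on MT4 cells (Homo sapiens) for cytotoxicity, read by MTT assay; on this read-out lower numbers stand for higher toxicity in this test and higher numbers for lower toxicity in this test:
- compound 1 `N#Cc1ccc(Nc2nc(Cc3c(F)cccc3F)cc(=O)[nH]2)cc1`: > 2500 nM (a limit)
- compound 2 `Cc1c(Cc2c(F)cccc2F)nc(Nc2ccc(C#N)cc2)[nH]c1=O`: > 2830 nM (a limit)
- compound 3 `Cc1c(N)nc(Nc2ccc(C#N)cc2)nc1Cc1c(F)cccc1F`: 45900 nM

Compound 1 stands at the limit of > 2500 nM in this assay, at which 1 of the 3 values shown sits, a limit and not a number. Compound 2 stands at the limit of > 2830 nM in this assay, at which 1 of the 3 values shown sits, likewise a limit. Going by the values given here, compound 3 carries the only true number in the set, 45900 nM.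

The next compound is compound 4 `CC(c1cc(=O)[nH]c(Nc2ccc(C#N)cc2)n1)c1c(F)cccc1F`, reached from compound 1 by methyl in place of hydrogen on a saturated chain carbon bound to two aromatic carbons.

Among the compounds with values here, one measured step bears on this change, and only loosely: a step that the two limits leave unreadable from compound 1 to compound 2. It also puts methyl in place of hydrogen, but on an aromatic carbon, so the place differs. Its size cannot be read, and it gives no direction for this assay. No step beyond the scatter can therefore be forecast from it. Compound 4 is expected to stay in the low-toxicity range of the set, and a limit is quite likely. Within the data shown here, the estimate leans on compound 3 at 45900 nM as the only number available. The expected step is a step that the limit leaves unreadable from compound 1 to compound 4, and its size is only loosely fixed. For compound 4 the estimated value is 10000 nM, with an expected range from 2500 nM to 50000 nM.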

Compound 4, half-maximal cytotoxic concentration: > 2830 nM
Compound 4: only a limit was reported; the forecaster's own chance of this, stated with the estimate: 60%; the middle value does not contradict the limit.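

In this assay, compound 1 and compound 4 are each reported only as a limit and not as a number, and the step between them cannot be read. The compounds shown leave open whether methyl in place of hydrogen on a saturated chain carbon bound to two aromatic carbons changes the half-maximal cytotoxic concentration at all, and in which direction.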